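Swapping the ring nitrogen's aryl cap for a cyclopropyl carbamate

The compounds below may be only part of what the source reports. "The series", "measured", "known", "first", "only" and "open" are said of these compounds alone.

Measured compounds:
- compound 1, `O=C(NC1(c2ccc3c(n2)CCN3c2ccnc(C(F)(F)F)n2)CCC1)c1ccc(Cl)cc1`, in an assay on blood for inhibition of Indoleamine 2,3-dioxygenase 1 (Homo sapiens) (a lower number here means a stronger inhibitor, a higher number a weaker inhibitor), compound 1 gives 240 nM
- compound 2, `O=C(C1CC1)N1CCc2nc(C3(C(=O)Nc4ccc(F)cc4)CCC3)ccc21`, compound 2 gives 330 nM
- compound 3, `O=C(c1cccc(Cl)c1)N1CCc2nc(C3(C(=O)Nc4ccc(F)cc4)CCC3)ccc21`, compound 3 gives 93 nM

Compound 1 stands second highest of the three numbers. Its nearest neighbour is compound 2, whose value lies within the usual scatter of that of compound 1, so no order between these two can be read from the numbers. Compound 3 sits further off, with a lower number than compound 1 that lies beyond the scatter.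

For the measured compounds named here, only one step between measured compounds is available: a 3.5-fold lower number from compound 2 to compound 3 (0.55 log units; beyond the scatter). That step concerns the group on the carbonyl carbon attached to the ring nitrogen of the shared core, where a small carbocycle was traded for a chlorinated aromatic ring.

The new compound is compound 4, `O=C(NC1(c2ccc3c(n2)CCN3C(=O)OC2CC2)CCC1)c1ccc(Cl)cc1`. It differs from compound 1 in one place: cyclopropyloxycarbonyl in place of 2-(trifluoromethyl)pyrimidin-4-yl on a nitrogen on an aromatic ring in a ring. The measured step runs the other way round in spirit, an aromatic ring giving a lower number than a cyclopropyl on a carbonyl. Compound 4 moves from an aromatic cap to a cyclopropyl-bearing carbamate, so a somewhat higher number is expected in this assay, a step of about a 2.3-fold higher number from compound 1 to compound 4 (0.36 log units; beyond the scatter). For compound 4 the estimate is 550 nM, with a range from 200 nM to 1500 nM.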

Compound 4, half-maximal inhibitory concentration: 63 nM
Estimate against measurement, compound 4: 8.7-fold (0.94 log units) above; the measured number lies below the stated range.
By their numbers in this assay, from the lowest: compounds 4 and 3 (each within the scatter of the next); then compounds 1 and 2 (each within the scatter of the next).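

At the nitrogen of the five-membered non-aromatic ring, an aromatic cap is not required for a low number in this assay: cyclopropyloxycarbonyl in place of 2-(trifluoromethyl)pyrimidin-4-yl gives a 3.8-fold lower number from compound 1 to compound 4 (0.58 log units; beyond the scatter). The earlier change at the corresponding nitrogen, 3-chlorophenyl in place of cyclopropyl on a carbonyl carbon, gave a 3.5-fold lower number from compound 2 to compound 3 (0.55 log units; beyond the scatter), so the two steps together do not support a general preference for an aromatic group at this place, and compound 4 goes against any such pattern. The compounds shown offer no measured finding that accounts for the direction or size of the new step.

As far as these compounds go, it remains open whether the lower number depends on the cyclopropyl ring, on the oxygen-linked carbonyl, or on both, which a methyl carbamate or a cyclopropanecarbonyl group at this nitrogen on the core of compound 1 would help to separate. Also open, from the compounds shown here alone, is whether cyclopropyloxycarbonyl would have a similar effect on the shared core of compound 2 and compound 3, and how a morpholine urea would compare at the same place.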